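The source may hold more compounds than are shown below. What is called first, only, known or untested is meant among the compounds shown, and "the series" means these compounds.

Three compounds share one core and differ only in the group attached through an amide to the outer benzene ring. Compound 1 `Cn1c(-c2ccc(NC(=O)CCl)cc2)nc(-c2ccccc2)c1-c1ccccc1` carries a chloro group on a saturated chain carbon bound to a carbonyl carbon; in a functional assay on MCF7 cells (Homo sapiens) for cytotoxicity, read by MTT assay, with a stated time of 24 h, tested at 16 ug/mL (a higher number here means a stronger effect of the compound at the concentration tested, a lower number a weaker effect), compound 1 gives 15.2%. Compound 2 `Cn1c(-c2ccc(NC(=O)CSc3nc4ccccc4s3)cc2)nc(-c2ccccc2)c1-c1ccccc1` has a (1,3-benzothiazol-2-yl)sulfanyl group in that place, and compound 2 gives 50.3%, a rise of a number 35.1 percentage points higher from compound 1 to compound 2 (beyond the scatter). Compound 3 `CN(C)/C=C/N1CCN(CC(=O)Nc2ccc(-c3nc(-c4ccccc4)c(-c4ccccc4)n3C)cc2)CC1` has a 4-(2-(dimethylamino)ethenyl)piperazin-1-yl group there; compound 3 gives 19.4%. Among the three numbers, compound 3 stands second highest, close to compound 1 with a step of a number 4.2 percentage points higher from compound 1 to compound 3 (within the scatter), and far from compound 2 with a step of a number 30.9 percentage points lower from compound 2 to compound 3 (beyond the scatter).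

Compound 4 `COc1ccc(CN2CCN(CC(=O)Nc3ccc(-c4nc(-c5ccccc5)c(-c5ccccc5)n4C)cc3)CC2)cc1` is the next step from compound 3: 4-methoxybenzyl in place of 2-(dimethylamino)ethenyl on an amine nitrogen in a ring. Among the compounds with values here, no measured step touches this amine nitrogen in a ring; the two steps that involve compound 3 swap the whole group on the chain carbon, and one of them is large while the other is within the scatter. Within the data shown here, because the only nearby comparison, a number 4.2 percentage points higher from compound 1 to compound 3 (within the scatter), is small, compound 4 is expected to move little, with an estimated step of a number 2.6 percentage points higher from compound 3 to compound 4 (within the scatter). Compound 4 is therefore estimated at 22%, in a range from 10% to 40%.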

Compound 4, a percentage reported as activity, at one concentration (the size of the read-out at that concentration, not a potency): 12%
Compound 4: the middle estimate sits 10 percentage points above what was measured; the measured number falls inside the stated range.
By their numbers in this assay, from the lowest: compounds 4, 1 and 3 (each within the scatter of the next); then compound 2.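

Within the data shown here, this is the first step that leaves the six-membered non-aromatic ring with 2 nitrogen in place and changes only what sits on its amine nitrogen. In this assay, exchanging the open 2-(dimethylamino)ethenyl group, with its double bond, for the larger 4-methoxybenzyl group, with its six-membered aromatic ring, gives a step of a number 7.4 percentage points lower from compound 3 to compound 4 (within the scatter). So this position accepts a clear change in the size and type of group without a readable change in the number, at least for this one pair, although two compounds cannot show how far that tolerance extends, and nothing measured here offers an explanation for it.

The compounds shown leave open whether a small group on this nitrogen, such as a methyl, or a group of a different kind, such as a carboxylic acid or a longer chain ending in an amine, would move the number beyond the scatter. They also leave open whether a plain benzyl group would behave like 4-methoxybenzyl, and whether a (1,3-benzothiazol-2-yl) ring placed on this nitrogen would bring a number closer to that of compound 2, 50.3%.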